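This account rests on a few compounds, and the source may have more. Where it says the series, first, only, none or still open, it means among the compounds named here.

Measured compounds:
compound 1, `COc1cc(-c2nnc3n2NC(c2cccs2)C(C(=O)c2ccc(F)cc2)S3)cc(OC)c1OC`, 27400 nM;
compound 2, `COc1cc(-c2nnc3n2NC(c2ccco2)C(C(=O)c2cccc(Br)c2)S3)cc(OC)c1OC`, 63900 nM;
compound 3, `COc1ccc(C(=O)C2Sc3nnc(-c4cc(OC)c(OC)c(OC)c4)n3NC2c2cccs2)cc1`, 95900 nM.

In a functional assay on PC-3 cells (Homo sapiens) for cytotoxicity, read by MTT assay, with a stated time of 48 h (on this read-out higher numbers stand for weaker inhibition and lower numbers for stronger inhibition), compound 2 gives 63900 nM, the second highest of the three numbers. Its nearest neighbour is compound 3 with 95900 nM, a gap within the scatter, while compound 1 with 27400 nM lies lower, beyond the scatter.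

Compound 4, `COc1cc(-c2nnc3n2NC(c2ccco2)C(C(=O)c2ccc(O)cc2)S3)cc(OC)c1OC`, has not been measured. It differs from compound 2 in one place: 4-hydroxyphenyl in place of 3-bromophenyl on a carbonyl carbon.

Within the data shown here, only one measured step bears on this change, and only loosely: a 3.5-fold higher number from compound 1 to compound 3 (0.54 log units; beyond the scatter). That step swaps a halogen for an oxygen-bearing group on the aryl attached to the carbonyl, and the number rose modestly. The present change also swaps a halogen for an oxygen-bearing group, though the groups and their positions on the ring differ, so the parallel is weak. A modest rise or no step beyond the scatter is therefore expected in this assay.

Compound 4 is expected to give about 90000 nM, within 40000 nM to 250000 nM. This corresponds to an expected step of a 1.4-fold higher number from compound 2 to compound 4 (0.15 log units; within the scatter).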

Compound 4, half-maximal inhibitory concentration: 38300 nM
Compound 4: the middle estimate sits 2.3-fold (0.37 log units) above what was measured, and the stated range ends above it.
By their numbers in this assay, from the lowest: compounds 1, 4, 2 and 3 (each within the scatter of the next, the first and the last beyond it).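

Replacing 3-bromophenyl with 4-hydroxyphenyl on the carbonyl carbon gives a 1.7-fold lower number from compound 2 to compound 4 (0.22 log units; within the scatter) in this assay, so this change, which also brings a hydrogen-bond donor, does not separate the two compounds in this read-out. The only earlier step at this position, a 3.5-fold higher number from compound 1 to compound 3 (0.54 log units; beyond the scatter), also put an oxygen-bearing group in place of a halogen but lay beyond the scatter, so that kind of exchange does not shift the number beyond the scatter in every case shown. No measurement is available that would explain the difference between these two steps.

The new step changes the substituent and its place on the ring together, so the compounds shown cannot separate the two effects. Going by these compounds, how an amine or a carboxylic acid on this phenyl ring would read in this assay also remains open.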